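The compounds below may be only part of what the source reports. "The series", "measured", "known", "first", "only" and "open" are said of these compounds alone.

Going by the values given here, compound 1 `CCCCCc1ccc(C#Cc2c(-c3ccc(CCCCC)cc3)oc3nc(=O)n(Cc4cn(-c5ccccc5F)nn4)cc23)cc1` gives the only numerical value seen so far in a functional assay on SW-620 cells (Homo sapiens) for antiproliferative activity, read by MTT assay, with a stated time of 72 h; on this read-out lower numbers stand for stronger inhibition and higher numbers for weaker inhibition; in this assay compound 1 gives 57100 nM. Compound 2 `CCCCCCc1cc2cn(Cc3cn(-c4ccccc4F)nn3)c(=O)nc2o1` gives > 100000 nM, which is a limit of the assay rather than a number: the limit of > 100000 nM in this assay, at which 1 of the 2 values shown sits. Compound 3 `CCCCCc1ccc(C#Cc2c(-c3ccc(CCCCC)cc3)oc3nc(=O)n(Cc4cn(-c5ccc(Cl)cc5)nn4)cc23)cc1` differs from compound 1 by 4-chlorophenyl in place of 2-fluorophenyl on an aromatic nitrogen, a 4-chlorophenyl in place of 2-fluorophenyl on an aromatic nitrogen. Among the compounds with values here, no measured pair shows what such a swap does here, so the expected step is a 1.1-fold lower number from compound 1 to compound 3 (0.06 log units; within the scatter), no larger than the scatter of this assay. Compound 3 is therefore estimated at 50000 nM, with a range from 20000 nM to 120000 nM.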

Compound 3, half-maximal inhibitory concentration: > 100000 nM
Compound 3 ended at the assay's limit (the forecaster's own chance of this, stated with the estimate: 30%); middle value at least 2.0-fold (0.30 log units) away from the limit.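

Going by these compounds alone, the first measured pair at this position is a swap on an aromatic nitrogen, 4-chlorophenyl in place of 2-fluorophenyl, and it gives an at least 1.7-fold higher number from compound 1 to compound 3 (0.24 log units; that floor lies within the scatter). Compound 3 gives > 100000 nM in this assay, which is a limit and not a number, so the swap shows no gain, and how large the loss is cannot be read. This ceiling now holds most of the series: the limit of > 100000 nM in this assay, at which 2 of the 3 values shown sit.

The swap changes both the halogen and where it sits, and these two changes cannot be separated here. On these data alone, whether an unsubstituted phenyl or an aminophenyl at this position would give a lower number remains open.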